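Cytotoxicity series: varying the group on the chloroacetamide carbon

A few compounds are considered here, and "the series" means these few. Any claim that something is new, unique, unknown or untested is made for them only; others in the source may bear on it.

Measured so far, in a functional assay on HT-29 cells (Homo sapiens) for cytotoxicity, read by MTT assay, with a stated time of 24 h, tested at 32 ug/mL; a higher number here means a stronger effect of the compound at the concentration tested, a lower number a weaker effect:
- compound 1 `Cn1c(-c2ccc(NC(=O)CCl)cc2)nc(-c2ccccc2)c1-c1ccccc1`: 53.2%
- compound 2 `Cn1c(-c2ccc(NC(=O)CSc3nc4cc(Cl)ccc4o3)cc2)nc(-c2ccccc2)c1-c1ccccc1`: 61.9%
- compound 3 `Cc1nnc(SCC(=O)Nc2ccc(-c3nc(-c4ccccc4)c(-c4ccccc4)n3C)cc2)s1`: 87.1%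

Compound 2 stands second highest of the three. Its nearest neighbour is compound 1, and that gap, a number 8.7 percentage points higher from compound 1 to compound 2 (within the scatter), is within the scatter. The larger gap is to compound 3, a number 25.2 percentage points higher from compound 2 to compound 3 (beyond the scatter), beyond the scatter.

Compound 4 `CN(C)/C=C/N1CCN(CC(=O)Nc2ccc(-c3nc(-c4ccccc4)c(-c4ccccc4)n3C)cc2)CC1` is not yet measured. It differs from compound 2 at one place:
4-(2-(dimethylamino)ethenyl)piperazin-1-yl in place of (5-chloro-1,3-benzoxazol-2-yl)sulfanyl on a saturated chain carbon bound to a carbonyl carbon

The measured steps that touch the same place are a number 8.7 percentage points higher from compound 1 to compound 2 (within the scatter) and a number 33.9 percentage points higher from compound 1 to compound 3 (beyond the scatter): both replace the chloro there with a heteroaryl sulfanyl group, one leaving the number within the scatter and one lifting it by a large amount. Going by the values given here, no measured step covers a non-aromatic ring, with no sulfur, at this place, so the direction cannot be read from the data. The step of a number 6.9 percentage points lower from compound 2 to compound 4 (within the scatter) is therefore estimated as small, of no sure direction, with a wide range. Compound 4 is expected to give 55%, between 30% and 80%.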

Compound 4, a percentage reported as activity, at one concentration (the size of the read-out at that concentration, not a potency): 29.8%
Estimate against measurement, compound 4: 25.2 percentage points above; measured number outside the range, below it.
By their numbers in this assay, from the lowest: compound 4; then compounds 1 and 2 (each within the scatter of the next); then compound 3.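

At this saturated chain carbon bound to a carbonyl carbon, the 4-(2-(dimethylamino)ethenyl)piperazin-1-yl group is the only replacement of chloro shown that lowers the number in this assay, with a number 23.4 percentage points lower from compound 1 to compound 4 (beyond the scatter) as its step. Against the two heteroaryl sulfanyl groups the fall is large as well, at a number 32.1 percentage points lower from compound 2 to compound 4 (beyond the scatter) and a number 57.3 percentage points lower from compound 3 to compound 4 (beyond the scatter), which makes compound 4 the weakest of the four and shows that this position can move the read-out strongly in both directions. No data bearing on the cause of this fall are available.

Still open, as far as these compounds go, is whether the fall belongs to the piperazine ring, to its ethenyl chain or to the loss of the sulfur. An unsubstituted piperazin-1-yl, a morpholin-4-yl and a phenylsulfanyl group at this place would separate these readings.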